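Nitro in place of hydrogen on compound 1

This account rests on a few compounds, and the source may have more. Where it says the series, first, only, none or still open, it means among the compounds named here.

Values so far in a functional assay on MDA-MB-231 cells (Homo sapiens) for antiproliferative activity, read by MTT assay, with a stated time of 72 h; a lower number here means a stronger inhibitor, a higher number a weaker inhibitor
- compound 1 `CC1=CC[C@H]2[C@H](CC[C@]2(C)O)C(C)(C)[C@@H]1CC[C@H]1[C@]2(C)CC[C@H](OC(=O)c3ccccc3)C(C)(C)O[C@H]2CC[C@@]1(C)O` gives 16100 nM
- compound 2 `CC1=CC[C@H]2[C@@H]1CC=C(C)[C@@H](CC[C@H]1[C@]3(C)CC[C@H](OC(=O)c4ccc(Cl)cc4)C(C)(C)O[C@H]3CC[C@@]1(C)O)C2(C)C` gives 12700 nM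
- compound 3 `CC1=CC[C@H]2[C@H](CC[C@]2(C)O)C(C)(C)[C@@H]1CC[C@H]1[C@]2(C)CC/C(=N/OC(=O)c3ccccc3)C(C)(C)O[C@H]2CC[C@@]1(C)O` gives 27400 nM

Compound 1 lies within the usual scatter of both compound 2 and compound 3, so its place among the three gives no ranking. Compound 4 `CC1=CC[C@H]2[C@H](CC[C@]2(C)O)C(C)(C)[C@@H]1CC[C@H]1[C@]2(C)CC[C@H](OC(=O)c3ccc([N+](=O)[O-])cc3)C(C)(C)O[C@H]2CC[C@@]1(C)O` keeps the core of compound 1 and carries nitro in place of hydrogen on an aromatic carbon, para to a large group (nitro in place of hydrogen on an aromatic carbon). For the measured compounds named here, no two measured compounds differ in one place, so no measured step can be carried over, and no change beyond the scatter is expected in this assay. The expected move (a 1.1-fold lower number from compound 1 to compound 4 (0.03 log units; within the scatter)) is small. Compound 4 is estimated at 15000 nM with an expected range from 7000 nM to 32000 nM in this assay.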

Compound 4, half-maximal inhibitory concentration: 8900 nM
Beside the measured number, compound 4's estimate is 1.7-fold (0.23 log units) above it, within the range that was stated.
By their numbers in this assay, from the lowest: compounds 4, 2, 1 and 3 (each within the scatter of the next, the first and the last beyond it).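

In this assay, for the compounds shown here, nitro in place of hydrogen on an aromatic carbon, para to a large group, gives the only single-place step, a 1.8-fold lower number from compound 1 to compound 4 (0.26 log units; within the scatter). Going by these compounds alone, this position therefore carries nitro on the core of compound 1 with no change beyond the scatter, which the earlier compounds, differing in more than one place, could not show. Nothing available here bears on the reason for this result.

On these data alone, whether an amine or a carboxylic acid at this position would move the number beyond the scatter remains open. So does whether nitro behaves alike on the core of compound 3.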